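Solubility of a pyridylmethylamine analogue with a dimethylphenyl group

The source may report more compounds than this note shows. Statements on the series, on what has been measured and on what is new or still open speak of the compounds shown alone.

Measured compounds:
Compound 1, `Cc1cc(NCc2ncccn2)n2nc(C)c(-c3ccccc3)c2n1` — 37900 nM
Compound 2, `Cc1cc(NCc2ccccn2)n2ncc(-c3ccc(N(C)C)cc3)c2n1` — < 5000 nM

Of the compounds shown here, two have been measured in a physicochemical assay for solubility, read by HPLC, using the shake flask method, measured as kinetic solubility, with a stated time of 2 h, at pH 7.4; on this read-out higher numbers stand for higher solubility and lower numbers for lower solubility. Compound 1, `Cc1cc(NCc2ncccn2)n2nc(C)c(-c3ccccc3)c2n1`, gives 37900 nM. Compound 2, `Cc1cc(NCc2ccccn2)n2ncc(-c3ccc(N(C)C)cc3)c2n1`, returns only a limit of the assay, < 5000 nM, so its true solubility is known only as a range. The two compounds differ in more than one place, so no single step between them is shown; the values simply show compound 1 with a measured number and compound 2 at the limit (the limit of < 5000 nM in this assay, at which 1 of the 2 values shown sits).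

Compound 3, `Cc1cc(NCc2ccccn2)n2ncc(-c3c(C)cccc3C)c2n1`, is not yet measured. It arises from compound 2 by the change (2,6-dimethylphenyl in place of 4-(dimethylamino)phenyl on an aromatic carbon). Nothing measured tells what this change does in this assay. With compound 2 itself at the limit, the account can only rest on that limit: compound 3 is expected to remain in the same low region, and the step from compound 2 to compound 3 is expected to be a step that the limit leaves unreadable from compound 2 to compound 3, which is not beyond the scatter. For compound 3 the estimate is 3000 nM, within a range of 800 nM to 12000 nM, and there is a fair chance that the assay will again report only a limit.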

Compound 3, solubility: < 5000 nM
Compound 3: a limit, no number; the forecaster's own chance of this, stated with the estimate: 60%; the middle value lies beyond the limit too.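

In this assay, among these compounds, compound 3 joins compound 2 at a limit, so no step between the two can be read: the limit of < 5000 nM in this assay, at which 2 of the 3 values shown sit.

The compounds shown leave open how far the true solubility of compound 2 and compound 3 lies beyond that limit, and whether 2,6-dimethylphenyl in place of 4-(dimethylamino)phenyl on an aromatic carbon changes it at all.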